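The source may report more compounds than this note shows. Statements on the series, on what has been measured and on what is new or still open speak of the compounds shown alone.

Measured compounds:
compound 1 `Nc1ccccc1NC(=O)c1ccc(COc2ccccc2)cc1` — 6760 nM
compound 2 `Nc1cc(F)ccc1NC(=O)c1ccc(COc2ccccc2)cc1` — 8340 nM

In a functional assay on A549 cells (Homo sapiens) for antiproliferative activity, read by CCK-8 assay, with a stated time of 72 h (a lower number here means a stronger inhibitor, a higher number a weaker inhibitor), compound 1 gives 6760 nM, the lowest of the two numbers shown; compound 2 gives 8340 nM. For the measured compounds named here, the one measured step, a 1.2-fold higher number from compound 1 to compound 2 (0.09 log units; within the scatter), lies within the scatter and concerns fluoro in place of hydrogen on an aromatic carbon, a different change from the one now at hand.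

Compound 3 `CC(C)c1ccc(OCc2ccc(C(=O)Nc3ccccc3N)cc2)cc1` differs from compound 1 in one place: isopropyl in place of hydrogen on an aromatic carbon. Going by the values given here, no measured step touches this part of the shared core, so the data give no direct anchor for the size or direction of the change. The single step that exists was flat, and nothing shown argues for a large move in either direction. The expected step of a 1.4-fold lower number from compound 1 to compound 3 (0.13 log units; within the scatter) is therefore small, with a modest lean toward a lower number held loosely. Compound 3 is expected to give 5000 nM in this assay, within a range from 1800 nM to 14000 nM.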

Compound 3, half-maximal inhibitory concentration: 7460 nM
Estimate against measurement, compound 3: 1.5-fold (0.17 log units) below; the measured number falls inside the stated range.
By their numbers in this assay, from the lowest: compounds 1, 3 and 2 (each within the scatter of the next).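

In this assay, for the compounds shown here, the step of a 1.1-fold higher number from compound 1 to compound 3 (0.04 log units; within the scatter) lies within the scatter, and it is the first reading at this position, on the far phenyl ring of compound 1 rather than on the ring that carries fluoro in compound 2. Going by these compounds alone, it shows that this aromatic carbon, para to a large group, can take isopropyl, with its 3 heavy atoms and no hydrogen-bond donors or acceptors, while the number stays within the scatter of the one for compound 1, so the change from phenyl to 4-isopropylphenyl leaves the two compounds indistinguishable in this read-out. Nothing available on these compounds accounts for this flat result, and the data offer no explanation for it.

The compounds shown leave open whether this flat reading holds for groups of another kind on the same carbon, such as an amine, a carboxylic acid or a longer alkyl chain, any of which might move the number beyond the scatter. They also leave open whether isopropyl would read the same way on the other carbons of that ring.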